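The compounds below may be only part of what the source reports. "The series", "measured", "known", "first", "only" and "open" are said of these compounds alone.

Measured in a functional assay on T98G cells (Homo sapiens) for cytotoxicity, read by MTT assay, with a stated time of 48 h; on this read-out higher numbers stand for weaker inhibition and lower numbers for stronger inhibition:
- Compound 1 `C[n+]1cccc(OP(=O)([O-])OC[C@H]2O[C@@H](n3cc(F)c(=O)[nH]c3=O)C[C@@H]2OC(=O)c2ccccc2)c1`: 3480 nM
- Compound 2 `CCOC(=O)C[n+]1cccc(OP(=O)([O-])OC[C@H]2O[C@@H](n3cc(F)c(=O)[nH]c3=O)C[C@@H]2OC(=O)c2ccccc2)c1`: 1600 nM

Compound 2 holds the lower number of the pair at 1600 nM. Compound 3 `C[N+]1(C)CCC(OP(=O)([O-])OC[C@H]2O[C@@H](n3cc(F)c(=O)[nH]c3=O)C[C@@H]2OC(=O)c2ccccc2)CC1` differs from it by a group of 8 heavy atoms (7 carbon, 1 nitrogen; one six-membered non-aromatic ring with 1 hetero atom) in place of a group of 12 heavy atoms (9 carbon, 1 nitrogen, 2 oxygen; one six-membered aromatic ring with 1 hetero atom), on an oxygen, on an oxygen whose other neighbours are phosphorus. Going by the values given here, only one measured step bears on this, the modest 2.2-fold lower number from compound 1 to compound 2 (0.34 log units; beyond the scatter), which introduced the ethoxycarbonyl that compound 3 lacks. Among the compounds with values here, no measured step covers the ring exchange, so the expectation is loose: a modest rise of similar size. The expected change is a 1.9-fold higher number from compound 2 to compound 3 (0.27 log units; within the scatter). For compound 3 the estimated value is 3000 nM, with an expected range of 1000 nM to 9000 nM.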

Compound 3, half-maximal inhibitory concentration: 6700 nM
For compound 3 the middle estimate is 2.2-fold (0.35 log units) below the measured one; the measured number falls inside the stated range.
By their numbers in this assay, from the lowest: compound 2; then compounds 1 and 3 (each within the scatter of the next).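

Within this assay, the group on the oxygen bound to phosphorus proved to matter when the non-aromatic ring replaced the ethoxycarbonyl-bearing aromatic ring, giving a 4.2-fold higher number from compound 2 to compound 3 (0.62 log units; beyond the scatter). Against the unsubstituted aromatic ring group the same non-aromatic ring gave only a 1.9-fold higher number from compound 1 to compound 3 (0.28 log units; within the scatter), so the ring exchange alone shows no clear change, and compound 2 keeps its lower number against both. Nothing available explains these differences. Still open, on these data alone, is how ethoxycarbonyl would read on the non-aromatic ring, and whether a carboxylic acid or a longer chain could replace it.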